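This account rests on a few compounds, and the source may have more. Where it says the series, first, only, none or still open, it means among the compounds named here.

Compound 3 `Cc1ccc(SCc2ccc(C(=O)Nc3ccccc3N)cc2)cc1` carries the amide of the shared core without the alkene linker, and in a functional assay on SMMC-7721 cells (Homo sapiens) for inhibition, read by CCK-8 assay, with a stated time of 72 h, tested at 2 uM (on this read-out lower numbers stand for less inhibition of growth and higher numbers for more inhibition of growth at the one concentration tested), compound 3 gives 25.1%. Two companions with the alkene linker frame it: compound 1 `Cc1ccc(SCc2ccc(/C=C/C(=O)Nc3ccccc3N)cc2)cc1` gives 22% in this assay, and compound 2 `Nc1ccccc1NC(=O)/C=C/c1ccc(CSc2ccc(Cl)cc2)cc1` gives 15.2%. Compound 3 thus holds the highest of the three numbers, yet its gaps to compound 1 and to compound 2 are both within the scatter, so no order among the three can be claimed. Going by the values given here, the one measured step, a number 6.8 percentage points lower from compound 1 to compound 2 (within the scatter), swaps a substituent on the aromatic ring joined to the sulfur and is itself within the scatter.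

Compound 4 `Nc1ccccc1NC(=O)c1ccc(CSCCc2ccccc2)cc1` differs from compound 3 in this way: phenethyl in place of 4-methylphenyl on a sulfur. Among the compounds with values here, no measured pair exchanges the aryl group on the sulfur for a chain-linked phenyl, so the only step that touches this region, from compound 1 to compound 2, is the nearest guide, and it moved nothing beyond the scatter. On that basis compound 4 is expected to stay close to compound 3, with an estimated step of a number 3.1 percentage points lower from compound 3 to compound 4 (within the scatter) in this assay. Compound 4 is therefore estimated at 22%, with a range from 8% to 38%.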

Compound 4, percent growth inhibition at one concentration: 28.1%
Beside the measured number, compound 4's estimate is 6.1 percentage points below it, within the range that was stated.
By their numbers in this assay, from the lowest: compounds 2, 1, 3 and 4 (each within the scatter of the next, the first and the last beyond it).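

In this assay, a number 3 percentage points higher from compound 3 to compound 4 (within the scatter) is within the scatter. This step goes further than the exchange between compound 1 and compound 2, which only swapped a substituent on the aromatic ring joined to the sulfur: here the whole 4-methylphenyl group on the sulfur gives way to phenethyl. The reading therefore does not separate compound 4 from compound 3, which shows that, in the shared core without the alkene linker, this larger exchange on the sulfur leaves growth inhibition at the one concentration tested indistinguishable from that of the 4-methylphenyl compound, and no evidence is available that would explain this outcome.

The compounds shown leave open whether a longer chain on the sulfur, or an amine or a carboxylic acid in place of phenethyl, would give a reading beyond the scatter from that of compound 4. They also leave open whether phenethyl on the sulfur would give a similar reading in the core of compound 1, which carries the alkene linker.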